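This account rests on a few compounds, and the source may have more. Where it says the series, first, only, none or still open, it means among the compounds named here.

Working notes on the series. In a functional assay on MDA-MB-231 cells (Homo sapiens) for cytotoxicity, read by MTT assay, with a stated time of 48 h (on this read-out lower numbers stand for stronger inhibition and higher numbers for weaker inhibition), compound 1 (`COc1cc(/C=C/c2ccc(OCCCC(=O)NO)cc2)cc(OC)c1`) gives 3890 nM and compound 2 (`COc1cc(/C=C/c2ccc(OCCCCC(=O)NO)cc2)cc(OC)c1`) gives 4210 nM. These two numbers lie within the scatter of each other, so compound 2 stands level with compound 1, and no order can be read between them.

Compound 3 (`COc1cc(/C=C/c2ccc(OCCCCCC(=O)NO)cc2)cc(OC)c1`) differs from compound 2 as follows: (hydroxycarbamoyl)methyl in place of hydroxycarbamoyl on a saturated chain carbon, four bonds along the chain from an oxygen on an aromatic ring. The change sits on a saturated chain carbon, four bonds along the chain from an oxygen on an aromatic ring.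

Going by the values given here, only one measured step bears on it, the same replacement made three bonds along the chain: a 1.1-fold higher number from compound 1 to compound 2 (0.03 log units; within the scatter), within the scatter. One step is thin evidence, but it gives no ground for expecting a shift beyond the scatter in this assay. The estimated step is a 1.1-fold lower number from compound 2 to compound 3 (0.04 log units; within the scatter). Compound 3 is expected at 3800 nM, with an estimated range from 1700 nM to 8000 nM.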

Compound 3, half-maximal inhibitory concentration: 3560 nM
Compound 3: middle estimate off by 1.1-fold (0.03 log units), on the high side, within the range that was stated.
By their numbers in this assay, from the lowest: compounds 3, 1 and 2 (each within the scatter of the next).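

The same replacement made four bonds along the chain gives a 1.2-fold lower number from compound 2 to compound 3 (0.07 log units; within the scatter) in this assay and so adds a second reading, at a further place on the chain, that stays within the scatter. The larger change, 2-(hydroxycarbamoyl)ethyl in place of hydroxycarbamoyl three bonds along the chain from the oxygen on the aromatic ring, gives a 1.1-fold lower number from compound 1 to compound 3 (0.04 log units; within the scatter) and is also within the scatter, so compound 1, compound 2 and compound 3 stand level, with no trend in chain length. Nothing at hand accounts for why these three chains read alike.

The compounds shown leave open whether a longer chain ending in hydroxycarbamoyl would stay level with these three. They also leave open whether a carboxylic acid or an amine in place of hydroxycarbamoyl would stay level.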